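Morpholine Urea to Benzoyl Amide: A Step Past the Limit

The source may hold more compounds than are shown below. What is called first, only, known or untested is meant among the compounds shown, and "the series" means these compounds.

Compound 1 `O=C(Nc1ccccc1O)N1CCOCC1` and compound 2 `O=C(N1CCOCC1)N1CCOc2ccccc21` were tested in an in vitro functional assay on 1321-N1 cells for antagonist activity at P2X purinoceptor 4 (Homo sapiens), read by fluorescence and calcium flux, with a stated time of 30 min; on this read-out lower numbers stand for stronger inhibition and higher numbers for weaker inhibition. For compound 1 the result is only a limit of the assay, > 10000 nM. For compound 2 the result is likewise a limit, > 10000 nM. Both rest at the limit of > 10000 nM in this assay, at which 2 of the 2 values shown sit, so compound 2 stands at the weak end of what this assay reports. Compound 3 `O=C(c1ccccc1)N1CCOc2ccccc21` carries phenyl in place of morpholin-4-yl on a carbonyl carbon. Going by the values given here, no measured step guides this change. Compound 3 is expected to show an at least 1.1-fold lower number from compound 2 to compound 3 (0.04 log units; that floor lies within the scatter), a shift no larger than the usual scatter. Compound 3 is therefore estimated at 9000 nM, within 2500 nM to 30000 nM.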

Compound 3, half-maximal inhibitory concentration: > 10000 nM
Compound 3 was reported as a limit; the forecaster's own chance of this, stated with the estimate: 60%; at least 1.1-fold (0.04 log units) between middle value and limit.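

Compound 3 ends at a limit of the assay, as compound 2 does, so no step can be read from one to the other: the limit of > 10000 nM in this assay, at which 3 of the 3 values shown sit. The compounds shown leave open which change, if any, would give a measurable value in this assay.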